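From a Fluoro Group to a Chlorophenyl Group

The compounds below may be only part of what the source reports. "The series", "measured", "known", "first", "only" and "open" are said of these compounds alone.

Measured compounds:
compound 1, `CC(C)(NC(=O)c1ccc([N+](=O)[O-])o1)c1ccc(Cl)cc1`, 81000 nM
compound 2, `CC(C)(C)c1ccc(C(C)(C)NC(=O)c2ccc([N+](=O)[O-])o2)cc1`, > 150000 nM
compound 3, `CC(C)(NC(=O)c1ccc([N+](=O)[O-])o1)c1ccc(F)cc1`, 42000 nM

The three compounds share one core and differ only in the group on the aromatic carbon of the pendant phenyl ring. In an ADME assay on Vero cells (Chlorocebus sabaeus) for cytotoxicity, read by MTT assay, with a stated time of 48 h (on this read-out higher numbers stand for lower toxicity in this test and lower numbers for higher toxicity in this test), compound 3 holds the lowest of the two numbers given; the nearest is compound 1, and the step of a 1.9-fold lower number from compound 1 to compound 3 (0.29 log units; within the scatter) lies within the scatter. For compound 2 the assay gives only a limit, (the limit of > 150000 nM in this assay, at which 1 of the 3 values shown sits).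

Compound 4, `CC(C)(NC(=O)c1ccc([N+](=O)[O-])o1)c1ccc(-c2ccc(Cl)cc2)cc1`, differs from compound 3 by 4-chlorophenyl in place of fluoro on an aromatic carbon. Among the measured compounds shown here, two measured steps bear on this change, both being exchanges of a small group for a larger one on the same carbon: an at least 1.8-fold higher number from compound 1 to compound 2 (0.26 log units; that floor lies within the scatter), which reaches the limit, and, read in reverse, an at least 3.5-fold lower number from compound 2 to compound 3 (0.55 log units; beyond the scatter), which is beyond the scatter. In both the larger group went with the higher number. The 4-chlorophenyl group of compound 4 is larger still than tert-butyl, so a higher number is expected, with a real chance that the assay again reports only a limit.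

The author therefore expects compound 4 to show a 2.4-fold higher number from compound 3 to compound 4 (0.38 log units; beyond the scatter), giving an estimate of 100000 nM with a range from 35000 nM to 150000 nM.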

Compound 4, half-maximal cytotoxic concentration: > 140000 nM
Compound 4 ended at the assay's limit; the forecaster's own chance of this, stated with the estimate: 40%; middle value at least 1.4-fold (0.14 log units) away from the limit.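

Replacing fluoro with 4-chlorophenyl gives an at least 3.3-fold higher number from compound 3 to compound 4 (0.52 log units; beyond the scatter) in this assay, so the higher number seen earlier with tert-butyl also appears with a group that brings a second six-membered aromatic ring of carbon only to this position. Exchanging chloro for 4-chlorophenyl gives an at least 1.7-fold higher number from compound 1 to compound 4 (0.23 log units; that floor lies within the scatter), and because that floor lies within the scatter, this pair does not show a clear separation, so the clear gain is established only against fluoro. The step between compound 2 and compound 4 cannot be read, as both values are limits, and compound 4 holds this one: the limit of > 140000 nM in this assay, at which 1 of the 4 values shown sits.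

From the compounds shown here alone, how far the true values of compound 2 and compound 4 lie beyond their limits remains open, so the two large groups cannot be placed in order. Also open is whether an amine, a carboxylic acid or a longer chain on this aromatic carbon would go with a higher number as tert-butyl and 4-chlorophenyl do, since the compounds shown carry only halogen, tert-butyl and 4-chlorophenyl groups there.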